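This account rests on a few compounds, and the source may have more. Where it says the series, first, only, none or still open, it means among the compounds named here.

Of the compounds shown here, three of one family have been measured, and a fourth awaits its number. Compound 1 `COc1ccc(/C=C/C(=O)C(=Cc2cc(Br)c(O)c(OC)c2)C(=O)/C=C/c2ccc(OC)cc2OC)c(OC)c1` and compound 2 `COc1ccc(/C=C/C(=O)C(=Cc2cc(OC)c(O)c(OC)c2)C(=O)/C=C/c2ccc(OC)cc2OC)c(OC)c1` share a core; compound 3 `COc1cc(OC)c(/C=C/C(=O)C(=Cc2cc(Br)c(O)c(OC)c2)C(=O)/C=C/c2c(OC)cc(OC)cc2OC)c(OC)c1` and compound 4 `COc1cc(OC)c(/C=C/C(=O)C(=Cc2cc(OC)c(O)c(OC)c2)C(=O)/C=C/c2c(OC)cc(OC)cc2OC)c(OC)c1` share another. In a functional assay on A549 cells (Homo sapiens) for antiproliferative activity, read by sulforhodamine B assay, with a stated time of 48 h (on this read-out higher numbers stand for weaker inhibition and lower numbers for stronger inhibition), compound 1 gives 1090 nM, while compound 2 gives 300 nM, so there was a 3.6-fold lower number from compound 1 to compound 2 (0.56 log units; beyond the scatter). That step comes from a single change, (methoxy in place of bromo on an aromatic carbon), in which the group that enters is described as follows: methoxy in place of bromo on an aromatic carbon. Compound 3 gives 730 nM in this assay, placing it close to compound 1 and apart from compound 2. How the core of compound 3 differs from the core of compound 1 is not broken down here.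

Compound 4 is related to compound 3 by exactly the same change: methoxy in place of bromo on an aromatic carbon. The surroundings of the altered position read the same in both pairs, so the change is the same, not merely the same kind. Among the compounds with values here, only one earlier example of it exists, and it sits on a different core, so the expectation rests on a single precedent. Because the earlier step was a 3.6-fold lower number from compound 1 to compound 2 (0.56 log units; beyond the scatter), a step of similar size is expected here, written as a 3.2-fold lower number from compound 3 to compound 4 (0.50 log units; beyond the scatter). On that basis compound 4 is estimated at 230 nM in this assay, with a plausible range from 110 nM to 500 nM, and the measured number is what follows.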

Compound 4, half-maximal inhibitory concentration: 340 nM
Compound 4: middle estimate off by 1.5-fold (0.17 log units), on the low side; the range from low to high includes it.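

Swapping bromo for methoxy on an aromatic carbon, which turns 3-bromo-4-hydroxy-5-methoxyphenyl into 4-hydroxy-3,5-dimethoxyphenyl, again lowers the number in this assay, with a 2.1-fold lower number from compound 3 to compound 4 (0.33 log units; beyond the scatter). Set side by side, the two steps point the same way, and the gap between their sizes is no larger than repeated measurements would be expected to produce: the same change on two cores in this assay, a 3.6-fold lower number (0.56 log units; beyond the scatter) from compound 1 to compound 2 and a 2.1-fold lower number (0.33 log units; beyond the scatter) from compound 3 to compound 4, 1.7-fold (0.23 log units) apart, within the scatter of two such steps. In these two pairs, then, the change carried over from one core to the other in direction and, as far as the scatter can tell, in size, but two pairs cannot establish a general rule, and they show neither why methoxy gives the lower number nor whether the same would hold on a third core.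

The compounds shown carry only bromo or methoxy at this position, so it remains open how a chlorine, an ethoxy group or an amine would behave there. The hydroxy group is also present in all four compounds, which leaves open whether the step would look the same on a ring with a methoxy group in its place.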